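The source may hold more compounds than are shown below. What is called first, only, known or untested is meant among the compounds shown, and "the series" means these compounds.

Measured in a functional assay on KB cells (Homo sapiens) for cytotoxicity, read by resazurin assay, with a stated time of 3 days; a higher number here means a weaker inhibitor, a lower number a stronger inhibitor:

- compound 1 `CCCCCCCC(=O)NCC(C)(C)CC1=C(O)C(=O)c2ccccc2C1=O`: 24600 nM
- compound 2 `CCCCCCCCCC(=O)NCC(C)(C)CC1=C(O)C(=O)c2ccccc2C1=O`: 18500 nM
- compound 3 `CCCC(C)C(=O)OCC(C)(C)CC1=C(O)C(=O)c2ccccc2C1=O`: 1760 nM

Compound 3 has the lowest number of the three, well beyond the scatter from both others. Compound 4 `CCCCCCCCC(=O)OCC(C)(C)CC1=C(O)C(=O)c2ccccc2C1=O` departs from compound 3 by one change: octyl in place of 1-methylbutyl on a carbonyl carbon. Going by the values given here, no measured step replaces 1-methylbutyl. The nearest evidence is a chain extension elsewhere, a 1.3-fold lower number from compound 1 to compound 2 (0.12 log units; within the scatter), and compound 1 and compound 2 also differ from compound 3 in more than the chain, so it bears only in part. On that evidence, no shift beyond the scatter is expected in this assay. The expected change is a 1.1-fold higher number from compound 3 to compound 4 (0.06 log units; within the scatter). For compound 4 the estimated value is 2000 nM, with an expected range of 600 nM to 7000 nM.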

Compound 4, half-maximal inhibitory concentration: 38700 nM
The estimate for compound 4 lay 19-fold (1.29 log units) below the measured number; measured number outside the range, above it.
By their numbers in this assay, from the lowest: compound 3; then compounds 2, 1 and 4 (each within the scatter of the next, the first and the last beyond it).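

In this assay the group on this carbonyl carbon clearly matters: octyl in place of 1-methylbutyl gives a 22-fold higher number from compound 3 to compound 4 (1.34 log units; beyond the scatter) as a large step. The earlier chain extension, a 1.3-fold lower number from compound 1 to compound 2 (0.12 log units; within the scatter), stayed within the scatter, so that step did not predict this one. Nothing measured here accounts for the change.

Octyl and 1-methylbutyl differ in both length and branching, and the compounds shown do not separate the two. From the compounds shown here alone, whether a straight butyl chain or a branched octyl chain would keep the lower number remains open.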